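The source may hold more compounds than are shown below. What is called first, only, known or untested is meant among the compounds shown, and "the series" means these compounds.

Measured so far in a functional assay on MCF7 cells (Homo sapiens) for cytotoxicity, read by sulforhodamine B assay; on this read-out lower numbers stand for stronger inhibition of growth and higher numbers for weaker inhibition of growth:
compound 1 `CC1=CC[C@@H]([C@@](C)(O)CCCC(C)(C)NC(=S)N/N=C\c2ccccc2)CC1` gives 7720 nM
compound 2 `CC1=CC[C@@H]([C@@](C)(O)CCCC(C)(C)NC(=S)N/N=C\c2ccccc2[N+](=O)[O-])CC1` gives 18600 nM

Going by the values given here, compound 2 stands at 18600 nM as the higher of the two numbers, and its only neighbour, compound 1, stands at 7720 nM on the same scale. The next compound, compound 3 `CC1=CC[C@@H]([C@@](C)(O)CCCC(C)(C)NC(=S)N/N=C\c2cccc(Cl)c2)CC1`, has not yet been measured. It differs from compound 2 as follows: 3-chlorophenyl in place of 2-nitrophenyl on a carbon with a double bond to nitrogen.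

Among the compounds with values here, only one measured step bears on this change. That step is a 2.4-fold higher number from compound 1 to compound 2 (0.38 log units; beyond the scatter), with nitro in place of hydrogen on an aromatic carbon, and it is modest but beyond the scatter. Compound 3 carries no nitro, so a modest move back towards the number of compound 1 seems likely. Within the data shown here, no measured step shows what a chlorine does on this series, which leaves the estimate wide. The expected change in this assay is a 2.0-fold lower number from compound 2 to compound 3 (0.29 log units; within the scatter), towards a lower number. Compound 3 is expected at 9500 nM (estimated range 4000 nM to 22000 nM).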

Compound 3, concentration for 50% growth inhibition: 7350 nM
Compound 3: middle estimate off by 1.3-fold (0.11 log units), on the high side, and the stated range covers the measured number.
By their numbers in this assay, from the lowest: compounds 3 and 1 (each within the scatter of the next); then compound 2.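

In this assay the exchange of 2-nitrophenyl for 3-chlorophenyl on the carbon with a double bond to nitrogen gives a 2.5-fold lower number from compound 2 to compound 3 (0.40 log units; beyond the scatter) and so shows that the aryl group at this place can shift the number beyond the scatter towards lower values, where the earlier step had shown only a shift towards higher ones. Going by these compounds alone, the move from plain phenyl to 3-chlorophenyl, which no earlier pair covered, gives a 1.1-fold lower number from compound 1 to compound 3 (0.02 log units; within the scatter) and leaves compound 3 and compound 1 within the scatter of each other, so among the three compounds only the 2-nitrophenyl group of compound 2 stands apart from the plain phenyl of compound 1. Nothing measured here explains either step.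

The compounds shown leave open whether a methoxy group or an amine on the phenyl ring would stay with compound 1 and compound 3 or go with compound 2, and they cannot separate the nitro from the place it holds, as the nitro and the chloro sit differently in compound 2 and compound 3. Going by these compounds, the shared core is the same throughout, so what a carboxylic acid or a longer chain there would do also stays open.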